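A trifluoromethyl arm where a fluorophenyl stood

The compounds below may be only part of what the source reports. "The series", "measured", "known", "first", "only" and "open" are said of these compounds alone.

Compound 2 `Oc1cccc(-c2cc(-c3ccc(F)cc3)cc(-c3ccccc3O)n2)c1` carries a 4-fluorophenyl group together with a 2-hydroxyphenyl group and a 3-hydroxyphenyl group on its core. In a functional assay on HeLa cells (Homo sapiens) for inhibition (on this read-out higher numbers stand for weaker inhibition and lower numbers for stronger inhibition), compound 2 gives only a limit, > 50000 nM. Compound 1 `Oc1cccc(-c2cc(-c3cccc(F)c3)cc(-c3ccccc3O)n2)c1`, its 3-fluorophenyl counterpart, also gives only a limit in this assay, > 50000 nM. The step that the two limits leave unreadable from compound 1 to compound 2 therefore cannot be read. Compound 3 `Oc1cccc(-c2cc(-c3ccc(F)cc3)cc(-c3cccc(O)c3)n2)c1`, in which 3-hydroxyphenyl stands in place of 2-hydroxyphenyl, gives 1280 nM in this assay, and the step of an at least 39-fold lower number from compound 2 to compound 3 (1.59 log units; beyond the scatter) is the only readable one; it concerns a different arm of the core. Compound 4 `Oc1cccc(-c2cc(-c3ccccc3C(F)(F)F)cc(-c3ccccc3O)n2)c1` differs from compound 2 as follows: 2-(trifluoromethyl)phenyl in place of 4-fluorophenyl on an aromatic carbon. Among the measured compounds shown here, no measured step touches this arm, and compound 4 keeps the 2-hydroxyphenyl group. Because the two compounds holding that group both sit at the limit of > 50000 nM in this assay, at which 2 of the 3 values shown sit, compound 4 is expected to stay at or near that limit, with the step that the limit leaves unreadable from compound 2 to compound 4 expected to be small. The estimate for compound 4 is 70000 nM, with a range from 20000 nM to 250000 nM.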

Compound 4, half-maximal inhibitory concentration: 16800 nM
For compound 4 the middle estimate is 4.2-fold (0.62 log units) above the measured one; the whole stated range lies above it.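

With the 2-hydroxyphenyl group kept, the arm opposite the ring nitrogen still moves the read-out in this assay: 2-(trifluoromethyl)phenyl in place of 4-fluorophenyl gives an at least 2.9-fold lower number from compound 2 to compound 4 (0.47 log units; beyond the scatter). Among the compounds shown here, in place of 3-fluorophenyl, the same group gives an at least 2.9-fold lower number from compound 1 to compound 4 (0.47 log units; beyond the scatter), and these are the first readable steps at this position. Compound 4 thus gives a number where the other two compounds holding the 2-hydroxyphenyl group stay at a limit of the assay: the limit of > 50000 nM in this assay, at which 2 of the 4 values shown sit.

As far as these compounds go, whether the trifluoromethyl group or its place on the phenyl ring carries these steps stays open, as does the true size of both, each being bounded by a limit. Also open, from the compounds shown here alone, is how an amine or a carboxylic acid on this arm would read, and how 2-(trifluoromethyl)phenyl would read with the 3-hydroxyphenyl group in place of the 2-hydroxyphenyl group.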